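Trimming the dimethylamino group of compound 3

The source may hold more compounds than are shown below. What is called first, only, known or untested is meant among the compounds shown, and "the series" means these compounds.

Measured in a functional assay on NCI-H1581 cells (Homo sapiens) for antiproliferative activity, read by CCK-8 assay, with a stated time of 72 h; a lower number here means a stronger inhibitor, a higher number a weaker inhibitor:
- Compound 1 `COc1cc(OC)c(Cl)c(-c2ccc3c(NC(=O)c4ccc(C5CCN(C)CC5)cc4)n[nH]c3n2)c1Cl`: 8.2 nM
- Compound 2 `CCN1CCN(c2ccc(C(=O)Nc3n[nH]c4nc(-c5c(Cl)c(OC)cc(OC)c5Cl)ccc34)cc2)CC1`: 0.7 nM
- Compound 3 `COc1cc(OC)c(Cl)c(-c2ccc3c(NC(=O)c4ccc(N(C)C)cc4)n[nH]c3n2)c1Cl`: 294 nM

Compound 3 has the highest number of the three, which makes it the weakest inhibitor here. Compound 4 `COc1cc(OC)c(Cl)c(-c2ccc3c(NC(=O)c4ccc(N)cc4)n[nH]c3n2)c1Cl` carries amino in place of dimethylamino on an aromatic carbon, para to a large group (amino in place of dimethylamino on an aromatic carbon).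

The measured steps at this place are all large: a 12-fold lower number from compound 1 to compound 2 (1.07 log units; beyond the scatter), a 36-fold higher number from compound 1 to compound 3 (1.55 log units; beyond the scatter) and a 420-fold higher number from compound 2 to compound 3 (2.62 log units; beyond the scatter). The last two lead to dimethylamino and both raise the number, but none reaches amino, so the direction is only a tentative expectation. A moderate rise in this assay is expected, with the estimated step being a 1.7-fold higher number from compound 3 to compound 4 (0.23 log units; within the scatter). For compound 4 the estimated value is 500 nM, with an expected range of 150 nM to 1600 nM.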

Compound 4, half-maximal inhibitory concentration: 218 nM
The estimate for compound 4 lay 2.3-fold (0.36 log units) above the measured number, and the stated range covers the measured number.
By their numbers in this assay, from the lowest: compound 2; then compound 1; then compounds 4 and 3 (each within the scatter of the next).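

In this assay, amino in place of dimethylamino gives a 1.3-fold lower number from compound 3 to compound 4 (0.13 log units; within the scatter), so the two small groups cannot be told apart at this position. Amino also stays far from the larger groups, with a 310-fold higher number from compound 2 to compound 4 (2.49 log units; beyond the scatter) and a 27-fold higher number from compound 1 to compound 4 (1.42 log units; beyond the scatter), which shows that the gap to 4-ethylpiperazin-1-yl and 1-methylpiperidin-4-yl does not depend on the methyl groups of dimethylamino. Nothing given here accounts for these results. Left open is where a morpholine or an unsubstituted piperazine would fall at this place, and whether a longer chain ending in dimethylamino would approach compound 1 or compound 2.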